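The source may hold more compounds than are shown below. What is called first, only, known or untested is meant among the compounds shown, and "the series" means these compounds.

Measured in a functional assay on SW-620 cells (Homo sapiens) for cytotoxicity, read by MTT assay, with stated times of 4 h and 72 h, tested at 2 uM; on this read-out lower numbers stand for stronger inhibition and higher numbers for weaker inhibition:
- compound 1 `Cc1cc(Nc2ccc(C(=O)/C=C/c3ccc(C(F)(F)F)cc3)cc2)n2nc(SCc3nc4ccccc4[nH]3)nc2n1` gives 1850 nM
- compound 2 `Cc1cc(Nc2ccc(C(=O)/C=C/c3ccccc3F)cc2)n2nc(SCc3nc4ccccc4[nH]3)nc2n1` gives 250 nM
- compound 3 `Cc1cc(Nc2ccc(C(=O)/C=C/c3ccc(-n4cccn4)cc3)cc2)n2nc(SCc3nc4ccccc4[nH]3)nc2n1` gives 340 nM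

Compound 3 sits together with compound 2 at the low end of these three numbers. Here a 1.4-fold higher number from compound 2 to compound 3 (0.13 log units; within the scatter) stays within the scatter, while a 5.4-fold lower number from compound 1 to compound 3 (0.74 log units; beyond the scatter) lies beyond it.

The next compound to be measured is compound 4 `Cc1cc(Nc2ccc(C(=O)/C=C/c3ccccc3Cl)cc2)n2nc(SCc3nc4ccccc4[nH]3)nc2n1`. The change from compound 3 is 2-chlorophenyl in place of 4-(1H-pyrazol-1-yl)phenyl on a double-bonded chain carbon bound to a double-bonded chain carbon, with 2-chlorophenyl in place of 4-(1H-pyrazol-1-yl)phenyl on a double-bonded chain carbon bound to a double-bonded chain carbon.

Among the compounds with values here, no measured compound carries 2-chlorophenyl, so the evidence is indirect. Three steps at this place bear on the change. Two are modest, a 7.4-fold lower number from compound 1 to compound 2 (0.87 log units; beyond the scatter) and the step to compound 3 already given, and both start from compound 1. The third, between the 2-fluorophenyl and 4-(1H-pyrazol-1-yl)phenyl compounds, is within the scatter. The closest measured group is the 2-fluorophenyl of compound 2 at 250 nM, so no large move is expected.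

The step expected in this assay is a 1.2-fold lower number from compound 3 to compound 4 (0.08 log units; within the scatter), which would be none beyond the scatter.

Compound 4 is estimated at 280 nM, with an expected range of 110 nM to 700 nM.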

Compound 4, half-maximal inhibitory concentration: 680 nM
Estimate against measurement, compound 4: 2.4-fold (0.39 log units) below; measured number inside the range.
By their numbers in this assay, from the lowest: compounds 2, 3 and 4 (each within the scatter of the next, the first and the last beyond it); then compound 1.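

In this assay, chloro in place of fluoro on an aromatic carbon is a change of a single atom in the group on the double-bonded chain carbon, yet a 2.7-fold higher number from compound 2 to compound 4 (0.43 log units; beyond the scatter) shows that this small change is enough to pass beyond the scatter. The earlier steps at this place all exchanged whole aryl groups, so this position now appears to respond to a single halogen swap, although the pair of compound 2 and compound 4 is the only such case shown. The 2-chlorophenyl group stays separated from 4-(trifluoromethyl)phenyl, with a 2.7-fold lower number from compound 1 to compound 4 (0.43 log units; beyond the scatter), while a 2.0-fold higher number from compound 3 to compound 4 (0.30 log units; within the scatter) does not separate it from 4-(1H-pyrazol-1-yl)phenyl, even though the group leaving is the larger one by the atom counts.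

With only two halogens in hand, no trend can be drawn: a bromo or a methoxy group on the same aromatic carbon, or a plain phenyl on the double-bonded chain carbon, would show whether fluoro or chloro is the exception. Nothing measured on these compounds accounts for the gap between the fluoro and chloro compounds.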